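Side-chain ether variation: from compound 3 to compound 4

The source may hold more compounds than are shown below. What is called first, only, known or untested is meant among the compounds shown, and "the series" means these compounds.

Measured compounds in an assay on brain for displacement of a labelled ligand from Adrenergic receptor alpha-1 (Rattus norvegicus); a higher number here means a weaker inhibitor, a lower number a stronger inhibitor:
Compound 1 `COCCOC1CCN(c2nc(N)c3cc(OC)c(OC)cc3n2)CC1`: 2.12 nM
Compound 2 `CCOCCOC1CCN(c2nc(N)c3cc(OC)c(OC)cc3n2)CC1`: 1.81 nM
Compound 3 `COc1cc2nc(N3CCC(OCCO)CC3)nc(N)c2cc1OC`: 2.2 nM

Compound 3 shows the highest of the three numbers, yet it is not separable from the others: the steps of a 1.0-fold higher number from compound 1 to compound 3 (0.02 log units; within the scatter) and a 1.2-fold higher number from compound 2 to compound 3 (0.08 log units; within the scatter) both fall within the scatter. Compound 4 `COc1cc2nc(N3CCC(OCC(C)(C)OC)CC3)nc(N)c2cc1OC` differs from compound 3 by 1-methoxy-1-methylethyl in place of hydroxymethyl on a saturated chain carbon bound to an oxygen on a saturated carbon. The measured steps that bear on it are the terminal extension a 1.2-fold lower number from compound 1 to compound 2 (0.07 log units; within the scatter) and the capping of the chain oxygen read in reverse, a 1.0-fold higher number from compound 1 to compound 3 (0.02 log units; within the scatter) and a 1.2-fold higher number from compound 2 to compound 3 (0.08 log units; within the scatter); all three are within the scatter. Compound 4 is therefore expected to move no further than a 1.2-fold higher number from compound 3 to compound 4 (0.07 log units; within the scatter), with no step beyond the scatter. The estimate for compound 4 in this assay is 2.6 nM, within 1.1 nM to 6.5 nM.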

Compound 4, inhibition constant: 1.14 nM
For compound 4 the middle estimate is 2.3-fold (0.36 log units) above the measured one; measured number inside the range.
By their numbers in this assay, from the lowest: compounds 4, 2, 1 and 3 (each within the scatter of the next).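

In this assay, 1-methoxy-1-methylethyl in place of hydroxymethyl gives a 1.9-fold lower number from compound 3 to compound 4 (0.29 log units; within the scatter), and the comparisons with the other ethers give a 1.6-fold lower number from compound 2 to compound 4 (0.20 log units; within the scatter) and a 1.9-fold lower number from compound 1 to compound 4 (0.27 log units; within the scatter). This saturated chain carbon therefore accepts a group of 5 heavy atoms with 0 hydrogen-bond donors, with no step beyond the scatter. No measurement here accounts for these steps. As far as these compounds go, whether an amine, a carboxylic acid or a longer chain at this place would also stay within the scatter remains open.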